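The compounds below may be only part of what the source reports. "The series", "measured", "known", "first", "only" and "open" are said of these compounds alone.

Two compounds carry measurements here. Compound 1 `N#C[C@@]1(NC(=O)[C@@H](CC(=O)N2CCOCC2)CC2Cc3ccccc3C2)CCN(C2CCCCC2)C1` gives 42 nM in an assay on isolated protein for inhibition of cathepsin S (Homo sapiens) (a higher number here means a weaker inhibitor, a lower number a stronger inhibitor), the lower of the two numbers. Compound 2 `CN1CC[C@@](C#N)(NC(=O)[C@@H](CC(=O)N2CCOCC2)CC2CCCCC2)C1` gives 155 nM in this assay, a number beyond the scatter from that of compound 1. Compound 3 `N#C[C@@]1(NC(=O)[C@@H](CC(=O)N2CCOCC2)CC2CCc3ccccc3C2)CCN(C2CCCCC2)C1` differs from compound 1 in one place: 1,2,3,4-tetrahydronaphthalen-2-yl in place of 2,3-dihydro-1H-inden-2-yl on a saturated chain carbon, two bonds along the chain from a carbonyl carbon. For the measured compounds named here, no measured pair shows this change. Since the ring that enters is one carbon larger than the one that leaves and otherwise alike, the step expected in this assay is a 1.2-fold higher number from compound 1 to compound 3 (0.08 log units; within the scatter), small and within the scatter. For compound 3 the estimate is 50 nM, with a range from 20 nM to 130 nM.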

Compound 3, half-maximal inhibitory concentration: 1.9 nM
Compound 3: middle estimate off by 26-fold (1.42 log units), on the high side; measured number outside the range, below it.
By their numbers in this assay, from the lowest: compound 3; then compound 1; then compound 2.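

Replacing 2,3-dihydro-1H-inden-2-yl with 1,2,3,4-tetrahydronaphthalen-2-yl on a saturated chain carbon, two bonds along the chain from a carbonyl carbon, gives a 22-fold lower number from compound 1 to compound 3 (1.34 log units; beyond the scatter) in this assay. For the compounds shown here, this shows that a change of one ring carbon at this position can move the number strongly, which the earlier compounds could not show. Nothing given here explains the step.

From the compounds shown here alone, whether a fluoro or methoxy group on the aromatic ring of 1,2,3,4-tetrahydronaphthalen-2-yl would keep this number remains open. Going by these compounds, the step also rests on one pair, so its size on other cores is unknown.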